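The compounds below may be only part of what the source reports. "The series", "measured", "known", "first", "only" and "open" are said of these compounds alone.

In a functional assay on HCT-116 cells (Homo sapiens) for cytotoxicity, read by scintillation counting and thymidine incorporation, with a stated time of 72 h (on this read-out higher numbers stand for weaker inhibition and lower numbers for stronger inhibition), compound 1 (`COc1cc(OC)cc(C(=CC(N)=O)c2ccc(OC)c(OC)c2)c1`) gives > 10000 nM as a limit, not a number. In this assay compound 2 (`C#CC=C(c1cc(OC)cc(OC)c1)c1ccc(OC)c(OC)c1`) gives > 10000 nM and so stands only at a limit. Compound 3 (`CCC=C(c1cc(OC)cc(OC)c1)c1ccc(OC)c(OC)c1`) has ethyl in place of ethynyl on a double-bonded chain carbon bound to a double-bonded chain carbon. Within the data shown here, the only measured step (a step that the two limits leave unreadable from compound 1 to compound 2) gives no size to carry over, so with the limit of > 10000 nM in this assay, at which 2 of the 2 values shown sit, as the sole guide, no step beyond the scatter is expected in this assay (a step that the limit leaves unreadable from compound 2 to compound 3 as estimated). Compound 3 is estimated at 12000 nM (expected range 4000 nM to 30000 nM) and may well be reported as a limit.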

Compound 3, half-maximal inhibitory concentration: > 10000 nM
Compound 3: only a limit was reported (the forecaster's own chance of this, stated with the estimate: 85%); the middle value lies beyond the limit too.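

Among these compounds, compound 1, compound 2 and compound 3 all stand only at a limit in this assay, so no step among them can be read. The compounds shown leave open whether any group at this double-bonded chain carbon gives a measurable value.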